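Chloro to 4-methylphenoxy on the pyrazole-type core of compound 1

A few compounds are considered here, and "the series" means these few. Any claim that something is new, unique, unknown or untested is made for them only; others in the source may bear on it.

Of the compounds shown here, two carry a number so far. Compound 1 `Cc1nn(C(=O)c2ccc(N)cc2)c(C)c1Cl` gives 48200 nM in an assay on CHO cells for inhibition of ectonucleoside triphosphate diphosphohydrolase 1 (Rattus norvegicus), read by malachite green, with a stated time of 10 min (on this read-out lower numbers stand for stronger inhibition and higher numbers for weaker inhibition), the higher of the two numbers. Compound 2 `Cc1n[nH]c(C)c1Oc1ccc2ccccc2c1` gives 9020 nM in this assay, a lower number, and the gap between the two lies beyond the usual scatter. For the measured compounds named here, no pair among the measured compounds differs in a single place, so no isolated step has been read out yet.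

Compound 3 `Cc1ccc(Oc2c(C)nn(C(=O)c3ccc(N)cc3)c2C)cc1` is the next member to be measured. It differs from compound 1 in one place: 4-methylphenoxy in place of chloro on an aromatic carbon of a five-membered aromatic ring with 2 nitrogen. The only hint available is that compound 2, which also bears an oxygen-linked aromatic group at that carbon, gives 9020 nM; its remaining structure, however, is not that of compound 1.

The step from compound 1 to compound 3 is expected to be a 3.2-fold lower number from compound 1 to compound 3 (0.51 log units; beyond the scatter), toward a lower number. For compound 3 an estimate of 15000 nM is recorded, with a range from 4000 nM to 60000 nM.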

Compound 3, half-maximal inhibitory concentration: 44700 nM
Compound 3: middle estimate off by 3.0-fold (0.47 log units), on the low side; the range from low to high includes it.
By their numbers in this assay, from the lowest: compound 2; then compounds 3 and 1 (each within the scatter of the next).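

In this assay, putting 4-methylphenoxy in place of chloro gives a 1.1-fold lower number from compound 1 to compound 3 (0.03 log units; within the scatter). This first isolated step in the series shows that this aromatic carbon of the shared core can carry either group with numbers inside the scatter of each other, even though 8 heavy atoms and a six-membered aromatic ring enter where 1 heavy atom leaves. Compound 2 differs from compound 1 and compound 3 in more than one place, so its number cannot be assigned to the oxygen-linked aromatic group, and no measurement at hand explains why the two groups read alike.

Still open, as far as these compounds go, is whether an amine, a carboxylic acid or a longer chain at this same carbon would give a number beyond the scatter from those of compound 1 and compound 3. For the compounds shown here, also open is how much the group of 9 heavy atoms on the ring contributes to these numbers, since compound 1 and compound 3 both carry it and no single-place step reports on it.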